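Series notes: a chloro step onto an unmeasured analogue

A few compounds are considered here, and "the series" means these few. Any claim that something is new, unique, unknown or untested is made for them only; others in the source may bear on it.

Measured in a functional assay on SW480 cells (Homo sapiens) for antiproliferative activity, read by MTT assay, with a stated time of 72 h; a lower number here means a stronger inhibitor, a higher number a weaker inhibitor:
compound 1 `O=c1c(SC(=S)N2CCCCC2)coc2ccccc12` gives 16300 nM
compound 2 `O=c1cc(CSC(=S)N2CCCC2)oc2ccccc12` gives 23400 nM
compound 3 `O=c1cc(CSC(=S)N2CCCC2)oc2cc(Cl)ccc12` gives a limit of the assay, > 25000 nM

Compound 1 and compound 2 are built from the same atoms joined differently; the difference between the two cores is not broken down here. Their two numbers in this assay stand within the scatter of each other. From compound 2 to compound 3 the change is chloro in place of hydrogen on an aromatic carbon, and the step is an at least 1.0-fold higher number from compound 2 to compound 3 (0.02 log units; that floor lies within the scatter). Compound 3 sits at the limit of > 25000 nM in this assay, at which 1 of the 3 values shown sits, which is a limit and not a number.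

The same change, (chloro in place of hydrogen on an aromatic carbon), leads from compound 1 to compound 4 `O=c1c(SC(=S)N2CCCCC2)coc2ccc(Cl)cc12`, not yet measured in this assay. For compound 4 the expected step is a 1.3-fold higher number from compound 1 to compound 4 (0.13 log units; within the scatter), since the same change gave an at least 1.0-fold higher number from compound 2 to compound 3 (0.02 log units; that floor lies within the scatter). Compound 4 is estimated at 22000 nM, between 10000 nM and 50000 nM.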

Compound 4, half-maximal inhibitory concentration: > 25000 nM
Compound 4 gave a limit, no number; the forecaster's own chance of this, stated with the estimate: 40%; middle value at least 1.1-fold (0.05 log units) away from the limit.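

Compound 4 gives > 25000 nM in this assay, which is a limit and not a number, so the chloro step on this core reads only as a floor: an at least 1.5-fold higher number from compound 1 to compound 4 (0.18 log units; that floor lies within the scatter). Carried from one core to the other, chloro in place of hydrogen gives no lower number on either core, but its size stays unknown on both, and whether it transfers unchanged is not shown: the same change on two cores in this assay, an at least 1.0-fold higher number (0.02 log units; that floor lies within the scatter) from compound 2 to compound 3 and an at least 1.5-fold higher number (0.18 log units; that floor lies within the scatter) from compound 1 to compound 4; the limit leaves it open whether they differ. Neither chloro compound gives a number to compare with its parent: the limit of > 25000 nM in this assay, at which 2 of the 4 values shown sit.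

Still open, on these data alone, is whether an amine or a methoxy group in place of the chloro would give a number inside the range of this assay on either core.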